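Swapping a fluorinated side group for a sulfur-bearing one

The source may report more compounds than this note shows. Statements on the series, on what has been measured and on what is new or still open speak of the compounds shown alone.

- compound 1 `CC#C[C@H]1CN(S(=O)(=O)c2ccc(N)nc2)CCN1c1ccc(S(=O)(=O)NC)cn1` gives 42 mL.min-1.g-1
- compound 2 `CC#C[C@H]1CN(S(=O)(=O)c2ccc(N)nc2)CCN1c1ccc(C(O)(COC)C(F)(F)F)cc1` gives 93 mL.min-1.g-1
- compound 3 `CC#C[C@H]1CN(S(=O)(=O)c2ccc(N)nc2)CCN1c1ncc(C(O)(C(F)(F)F)C(F)(F)F)cn1` gives 28 mL.min-1.g-1

These numbers come from an ADME assay (liver) for metabolic stability, with Liver microsome (Rattus norvegicus) as the target, using microsomes and NADPH, with a stated time of 30 min; on this read-out lower numbers stand for slow clearance and higher numbers for fast clearance. Compound 2 has the highest number of the three at 93 mL.min-1.g-1. Compound 1 lies nearest to it and compound 3 furthest, and both gaps go beyond the usual scatter of repeat measurements.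

Compound 4 `CC#C[C@H]1CN(S(=O)(=O)c2ccc(N)nc2)CCN1c1ccc(S(=N)(=O)C2CC2)cc1` has not been measured yet. It differs from compound 2 as follows: a group of 6 heavy atoms (3 carbon, 1 nitrogen, 1 oxygen, 1 sulfur; one three-membered non-aromatic ring of carbon only) in place of a group of 9 heavy atoms (4 carbon, 2 oxygen, 3 fluorine; no ring), on an aromatic carbon. The swap sits on an aromatic carbon, para to a large group.

For the measured compounds named here, no two measured compounds differ in one place only, so any expectation rests on a loose comparison. Compound 1, which also carries a sulfur-bearing group, gives 42 mL.min-1.g-1, and this points to a moderately lower number in this assay, somewhat beyond the scatter. The estimated change is a 2.3-fold lower number from compound 2 to compound 4 (0.37 log units; beyond the scatter). For compound 4 the expected value is 40 mL.min-1.g-1, with an estimated range of 18 mL.min-1.g-1 to 85 mL.min-1.g-1.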

Compound 4, intrinsic clearance in microsomes: 23 mL.min-1.g-1
Compound 4: middle estimate off by 1.7-fold (0.24 log units), on the high side; the measured number falls inside the stated range.
By their numbers in this assay, from the lowest: compounds 4, 3 and 1 (each within the scatter of the next); then compound 2.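

Read in this assay, exchanging the group on an aromatic carbon, para to a large group, gives a 4.0-fold lower number from compound 2 to compound 4 (0.61 log units; beyond the scatter). For the compounds shown here, this is the first comparison here in which only one place changes, so it shows that the group at this position can alter the clearance number on its own, with the rest of the molecule held constant. Both groups have the same counts of hydrogen-bond donors and acceptors, but nothing available here explains the step.

On these data alone, it remains open whether the step follows from the sulfur-bearing part or from the three-membered ring, a question that a methyl or an ethyl chain in place of that ring could help to separate. As far as these compounds go, it also remains open whether the same exchange would give a similar step on a different aromatic ring.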